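A Ring Methyl Carried From One Amide to Another

The compounds below may be only part of what the source reports. "The series", "measured", "known", "first", "only" and "open" are said of these compounds alone.

Measured compounds:
- compound 1, `COc1cc2c(Oc3ccc(NC(=O)c4nnn(-c5ccccc5)c4C)cc3F)ccnc2cc1OCCCN1CCCCC1`, in a functional assay on MKN-45 cells (Homo sapiens) for cytotoxicity, read by MTT assay, with a stated time of 72 h (on this read-out higher numbers stand for weaker inhibition and lower numbers for stronger inhibition), gives 80 nM
- compound 2, `COc1cc2c(Oc3ccc(NC(=O)c4nnn(-c5ccc(F)cc5)c4C(F)(F)F)cc3F)ccnc2cc1OCCCN1CCCCC1`, in this assay gives 40 nM
- compound 3, `COc1cc2c(Oc3ccc(NC(=O)c4nnn(-c5ccccc5)c4C)cc3F)ccnc2cc1OCCCN1CCC(C)CC1`, in this assay gives 90 nM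

Compound 1 and compound 3 differ in one place: methyl in place of hydrogen on a saturated ring carbon. That change gave a 1.1-fold higher number from compound 1 to compound 3 (0.05 log units; within the scatter), a step that lies within the usual scatter of repeated measurements, so the two numbers are not told apart by this assay.

Compound 2 carries a different core; how the core of compound 2 differs from the core of compound 1 is not broken down here. Its number in this assay is the lowest of the three measured, but the gap to compound 1 is within the scatter and only the gap to compound 3 goes beyond it, so nothing firm is read into the order.

Compound 4, `COc1cc2c(Oc3ccc(NC(=O)c4nnn(-c5ccc(F)cc5)c4C(F)(F)F)cc3F)ccnc2cc1OCCCN1CCC(C)CC1`, is not yet measured. It stands to compound 2 as compound 3 stands to compound 1: methyl in place of hydrogen on a saturated ring carbon. The two place descriptions agree word for word, so this is the same change, made on the core of compound 2 instead of the core of compound 1.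

On the evidence of the earlier pair, compound 4 is expected to move little from compound 2, about a 1.1-fold higher number from compound 2 to compound 4 (0.05 log units; within the scatter), because the same change gave a 1.1-fold higher number from compound 1 to compound 3 (0.05 log units; within the scatter). Compound 4 is therefore estimated at 45 nM in this assay. Within the data shown here, the range for compound 4 is expected to run from 20 nM to 100 nM, resting only on the single earlier step and on the value of compound 2, 40 nM.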

Compound 4, half-maximal inhibitory concentration: 70 nM
For compound 4 the middle estimate is 1.6-fold (0.19 log units) below the measured one; the range from low to high includes it.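

In this assay, replacing piperidin-1-yl with 4-methylpiperidin-1-yl on the core of compound 2 gave a 1.8-fold higher number from compound 2 to compound 4 (0.24 log units; within the scatter), so on this core, as on the core of compound 1, the assay does not tell the compounds with and without the methyl apart. Set side by side, the two steps do not differ by more than repeated measurements would allow: the same change on two cores in this assay, a 1.1-fold higher number (0.05 log units; within the scatter) from compound 1 to compound 3 and a 1.8-fold higher number (0.24 log units; within the scatter) from compound 2 to compound 4, 1.6-fold (0.19 log units) apart, within the scatter of two such steps. Among these compounds, the methyl can therefore be carried between these two cores without a readable change in this cytotoxicity read-out on either one, but the result rests on only two pairs and does not show that the methyl has no effect on other cores or in other assays.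

The compounds shown leave open whether the same tolerance would hold for a different group on that saturated ring carbon, such as a hydroxyl, a dimethylamine or a carboxylic acid, none of which appears here. They also leave open what would happen if the piperidine itself gave way to a morpholine or a piperazine, or if a longer or shorter chain linked that ring to the core.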